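The source may hold more compounds than are shown below. What is called first, only, known or untested is meant among the compounds shown, and "the series" means these compounds.

In a functional assay on A549 cells (Homo sapiens) for antiproliferative activity, read by sulforhodamine B assay, with a stated time of 48 h (on this read-out higher numbers stand for weaker inhibition of growth and lower numbers for stronger inhibition of growth), three compounds have been measured.
Compound 1 `CC(C)CCc1c(OCCCCCCCC(=O)NO)ccc2ccc(=O)oc12` gives 2190 nM.
Compound 2 `CC(C)CCc1c(OCCCCCCC(=O)NO)ccc2ccc(=O)oc12` gives 660 nM.
Compound 3 `CC(C)CCc1c(OCCCCCC(=O)NO)ccc2c1OC(=O)CC2` is reported only as a limit of the assay, > 30000 nM.

Compound 1 and compound 2 differ by hydroxycarbamoyl in place of (hydroxycarbamoyl)methyl on a saturated chain carbon, six bonds along the chain from an oxygen on an aromatic ring, and that change produced a 3.3-fold lower number from compound 1 to compound 2 (0.52 log units; beyond the scatter). The same kind of change leads from compound 3 to compound 4 `CC(C)CCc1c(OCCCCC(=O)NO)ccc2c1OC(=O)CC2`, which is not yet measured: hydroxycarbamoyl in place of (hydroxycarbamoyl)methyl on a saturated chain carbon, four bonds along the chain from an oxygen on an aromatic ring. The places are not identical: in compound 1 the group sits six bonds along the chain from an oxygen on an aromatic ring, in compound 3 four bonds along, so it is the same kind of change, not the same. How the core of compound 3 differs from that of compound 1 is not broken down here. Compound 3 stands at the limit of > 30000 nM in this assay, at which 1 of the 3 values shown sits, so its step cannot be fixed. Because a 3.3-fold lower number from compound 1 to compound 2 (0.52 log units; beyond the scatter) was modest and the starting point is a limit, compound 4 is expected to show an at least 1.2-fold lower number from compound 3 to compound 4 (0.07 log units; that floor lies within the scatter). The estimate for compound 4 is 25000 nM, between 8000 nM and 100000 nM.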

Compound 4, concentration for 50% growth inhibition: > 30000 nM
Compound 4 ended at the assay's limit; the forecaster's own chance of this, stated with the estimate: 55%; middle value at least 1.2-fold (0.07 log units) from the limit.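

Compound 3 and compound 4 both sit at the assay's limit, so no step between them can be read: the limit of > 30000 nM in this assay, at which 2 of the 4 values shown sit.

Going by these compounds, whether hydroxycarbamoyl in place of (hydroxycarbamoyl)methyl changes anything on the core of compound 3 in this assay stays open.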